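Methoxy for fluoro on the pendant phenyl of compound 3

The source may hold more compounds than are shown below. What is called first, only, known or untested is meant among the compounds shown, and "the series" means these compounds.

Measured compounds:
compound 1 `CN1C(=O)C(C2CC2)N(C)c2nc(Nc3ccc(S(N)(=O)=O)cc3)ncc21`: 136 nM
compound 2 `CN1C(=O)C(c2ccc(F)cc2)N(C)c2nc(Nc3ccc(S(N)(=O)=O)cc3)ncc21`: 1770 nM
compound 3 `CN1C(=O)C(c2cccc(F)c2)N(C)c2nc(Nc3ccc(S(N)(=O)=O)cc3)ncc21`: 134 nM

In an assay on Sf9 cells for inhibition of serine/threonine-protein kinase 4 (Homo sapiens), read by luminescence and ADP-Glo, with a stated time of 1 h, in the presence of a further agent that is not named here (a higher number here means a weaker inhibitor, a lower number a stronger inhibitor), compound 3 gives the lowest number of the three, but it sits within the scatter of compound 1, which gives 136 nM; compound 2 gives 1770 nM. The steps of a 1.0-fold lower number from compound 1 to compound 3 (0.01 log units; within the scatter) and a 13-fold lower number from compound 2 to compound 3 (1.12 log units; beyond the scatter) show that the 3-fluorophenyl and cyclopropyl groups read alike, while the 4-fluorophenyl reads far weaker. Compound 4 `COc1cccc(C2C(=O)N(C)c3cnc(Nc4ccc(S(N)(=O)=O)cc4)nc3N2C)c1` carries the change (methoxy in place of fluoro on an aromatic carbon). Going by the values given here, no measured step exchanges fluoro for methoxy, so the 3-fluorophenyl and 4-fluorophenyl steps bear on it only loosely. The estimate for compound 4 is 160 nM, with a range from 50 nM to 550 nM, a step of a 1.2-fold higher number from compound 3 to compound 4 (0.08 log units; within the scatter) expected to stay within the scatter.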

Compound 4, half-maximal inhibitory concentration: 954 nM
Compound 4: middle estimate off by 6.0-fold (0.78 log units), on the low side; measured number outside the range, above it.
By their numbers in this assay, from the lowest: compounds 3 and 1 (each within the scatter of the next); then compounds 4 and 2 (each within the scatter of the next).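

In this assay, going by these compounds alone, the step of a 7.1-fold higher number from compound 3 to compound 4 (0.85 log units; beyond the scatter) shows that the group on this aromatic carbon matters, which the earlier compounds, with only fluoro there, could not show. The step of a 7.0-fold higher number from compound 1 to compound 4 (0.85 log units; beyond the scatter) shows that the match between 3-fluorophenyl and cyclopropyl does not extend to 3-methoxyphenyl, while the step of a 1.9-fold lower number from compound 2 to compound 4 (0.27 log units; within the scatter) places 3-methoxyphenyl level with 4-fluorophenyl. No evidence is available that bears on this result.

On these data alone, whether chloro, methyl or hydroxyl on this carbon would read like fluoro or like methoxy stays open.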